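Cytotoxicity Limits Across a Benzyl Swap

The source may report more compounds than this note shows. Statements on the series, on what has been measured and on what is new or still open speak of the compounds shown alone.

Measured compounds:
compound 1 `COC(=O)c1ccc(NCc2cncn2Cc2cccc(Cl)c2)cc1-c1ccccc1` — > 10000 nM, a limit
compound 2 `CC(C)OC(=O)c1ccc(NCc2cncn2Cc2ccc(-c3ccccc3)cc2)cc1-c1ccccc1` — > 10000 nM, a limit
compound 3 `COc1ccc(NCc2cncn2Cc2ccc(-c3ccccc3)cc2N)cc1-c1ccccc1` — > 1000 nM, a limit

All three measured compounds were tested in a toxicity assay on NIH3T3 cells (Mus musculus) for cytotoxicity, read by resazurin assay; a higher number here means that more compound is needed for the effect, a lower number that less compound is needed. Compound 1 gives only a limit there, > 10000 nM. Compound 2 likewise gives a limit, > 10000 nM. Compound 3 gives a limit at a lower threshold, > 1000 nM. So compound 1 stands among the values shown as one of the two at the limit of > 10000 nM in this assay, at which 2 of the 3 values shown sit, while the limit of > 1000 nM in this assay, at which 1 of the 3 values shown sits, holds the third. Going by the values given here, no number exists for any of them, and no step between measured compounds can be computed.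

Compound 4 `COC(=O)c1ccc(NCc2cncn2Cc2ccc(F)cc2F)cc1-c1ccccc1` has not been measured. It differs from compound 1 in one place: 2,4-difluorophenyl in place of 3-chlorophenyl on a saturated chain carbon bound to an aromatic nitrogen. The halogen-bearing ring changes from 3-chlorobenzyl to 2,4-difluorobenzyl while the rest of the core of compound 1 is kept. With only limits for all measured compounds, nothing indicates a step beyond the scatter, and the expected step that the limit leaves unreadable from compound 1 to compound 4 is none beyond it. An outcome that is again a limit is the most likely. Compound 4 is therefore expected at 15000 nM, within 5000 nM to 50000 nM in this assay.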

Compound 4, half-maximal effective concentration: > 1000 nM
Compound 4: a limit, no number (the forecaster's own chance of this, stated with the estimate: 85%); the middle value lies beyond the limit too.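

Compound 1 and compound 4 both give only limits in this assay, so the step between them cannot be read. The compounds shown leave open whether 2,4-difluorobenzyl in place of 3-chlorobenzyl changes the concentration needed for cytotoxicity at all, and at what concentration, if any, either compound reaches the half-maximal effect.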